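From 4-Bromophenyl to 2,3-Dichlorophenyl on a Shared Core

The source may hold more compounds than are shown below. What is called first, only, known or untested is meant among the compounds shown, and "the series" means these compounds.

Compound 1 `COc1cccc(/C=C2\CCC/C(=C\c3cccc(Br)c3)C2=O)c1OC` gives 11700 nM
Compound 2 `COc1cccc(/C=C2\CCC/C(=C\c3ccc(Br)cc3)C2=O)c1OC` gives 13800 nM

In a functional assay on MCF7 cells (Homo sapiens) for cytotoxicity, read by MTT assay, with a stated time of 72 h (a lower number here means a stronger inhibitor, a higher number a weaker inhibitor), compound 2 gives 13800 nM and stands level with compound 1 within the scatter. Compound 3 `COc1cccc(/C=C2\CCC/C(=C\c3cccc(Cl)c3Cl)C2=O)c1OC` carries 2,3-dichlorophenyl in place of 4-bromophenyl on a double-bonded chain carbon bound to a double-bonded ring carbon and awaits measurement. Among the compounds with values here, the one measured step at this place is a 1.2-fold higher number from compound 1 to compound 2 (0.07 log units; within the scatter) and it exchanged 3-bromophenyl for 4-bromophenyl. Within the data shown here, no measured compound carries 2,3-dichlorophenyl, so no direction can be argued, and no step beyond the scatter is expected in this assay here. The estimated step is a 1.2-fold lower number from compound 2 to compound 3 (0.06 log units; within the scatter) for this change. Compound 3 is expected at 12000 nM (estimated range 5000 nM to 28000 nM).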

Compound 3, half-maximal inhibitory concentration: > 20000 nM
Compound 3 gave a limit, no number (the forecaster's own chance of this, stated with the estimate: 5%); at least 1.6-fold (0.22 log units) between middle value and limit.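

In this assay compound 3 gives a limit and not a number: the limit of > 20000 nM in this assay, at which 1 of the 3 values shown sits.

Replacing either bromophenyl group with 2,3-dichlorophenyl gives an at least 1.4-fold higher number from compound 2 to compound 3 (0.16 log units; that floor lies within the scatter) and an at least 1.7-fold higher number from compound 1 to compound 3 (0.23 log units; that floor lies within the scatter). This place therefore now holds a group that yields no number, yet neither floor shows a step beyond the scatter, so a real loss is not established.

From the compounds shown here alone, how far compound 3 lies past its limit stays open. So does whether an amine or a carboxylic acid at this place would give a lower number in this assay.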